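The source may hold more compounds than are shown below. What is called first, only, known or untested is meant among the compounds shown, and "the series" means these compounds.

Compounds measured so far:
compound 1, `CN1CCN(CCCNCc2cn(-c3ccc([N+](=O)[O-])cc3)nc2-c2ccc(OC(F)(F)F)cc2)CC1`: 1600 nM
compound 2, `CN1CCN(CCNCc2cn(-c3ccc(F)cc3F)nc2-c2ccc(OC(F)(F)F)cc2)CC1`: 18000 nM
compound 3, `CN1CCN(CCNCc2cn(-c3ccc(F)cc3F)nc2-c2ccc(S(=O)(=O)N(C)C)cc2)CC1`: > 20000 nM

The three measured compounds share one core and were tested in an ADME assay on Huh-7 cells (Homo sapiens) for cytotoxicity; a lower number here means that less compound is tolerated, a higher number that more compound is tolerated. Compound 1 gives 1600 nM and compound 2 gives 18000 nM in this assay. For compound 3 this assay reports only a limit, > 20000 nM. Compound 3 therefore stands at the upper edge of the numbers shown; the one measured step that touches it, an at least 1.1-fold higher number from compound 2 to compound 3 (0.04 log units; that floor lies within the scatter), is set by that limit, as the limit of > 20000 nM in this assay, at which 1 of the 3 values shown sits, records, and does not reach beyond the scatter.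

The next compound, compound 4, `COc1ccc(-c2nn(-c3ccc(F)cc3F)cc2CNCCN2CCN(C)CC2)cc1`, is to be measured in this assay. It differs from compound 3 in one place: methoxy in place of dimethylsulfamoyl on an aromatic carbon. For the measured compounds named here, no measured step swaps these two groups directly. Going by the values given here, the only step on the same aromatic carbon is an at least 1.1-fold higher number from compound 2 to compound 3 (0.04 log units; that floor lies within the scatter), which exchanges trifluoromethoxy for dimethylsulfamoyl and is read as lying within the scatter. On that evidence, compound 4 is expected to give 16000 nM in this assay, with a range from 5000 nM to 30000 nM. The expected step is an at least 1.2-fold lower number from compound 3 to compound 4 (0.09 log units; that floor lies within the scatter), which is no change beyond the scatter, and a limit rather than a number remains a real possibility.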

Compound 4, half-maximal cytotoxic concentration: > 20000 nM
Compound 4 was reported as a limit; the forecaster's own chance of this, stated with the estimate: 35%; at least 1.2-fold (0.09 log units) between middle value and limit.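

In this assay, the change from dimethylsulfamoyl to methoxy cannot be read, as both of its ends are limits. For the compounds shown here, the one readable step is an at least 1.1-fold higher number from compound 2 to compound 4 (0.04 log units; that floor lies within the scatter); putting methyl in place of trifluoromethyl on the oxygen on the aromatic ring therefore shows no change beyond the scatter, and only the floor of this step is known. What compound 4 adds is that dimethylsulfamoyl is not the only group on this aromatic carbon, para to a large group, to reach the limit, since methoxy, with its 2 heavy atoms against 6, reaches it too: the limit of > 20000 nM in this assay, at which 2 of the 4 values shown sit.

As far as these compounds go, how far compound 3 and compound 4 each lie beyond that limit stays open, so the groups at this position cannot be placed in order. From the compounds shown here alone, it also stays open whether an amine or a carboxylic acid on this aromatic carbon would give a number rather than a limit in this assay.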